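Chromanone series: benzyl ether replaced by methoxymethyl ether

The compounds below may be only part of what the source reports. "The series", "measured", "known", "first", "only" and "open" are said of these compounds alone.

Measured so far:
compound 1, `O=C1CC(c2ccccc2OCc2ccccc2)Oc2ccccc21`: 91.5%
compound 2, `O=C1CC(c2ccccc2OCc2cccc(F)c2)Oc2ccccc21`: 92.7%

In a functional assay on J774.A1 cells (Mus musculus) for inhibition, read by immunoassay, with a stated time of 12 h, tested at 30 uM (on this read-out lower numbers stand for less inhibition and higher numbers for more inhibition at the one concentration tested (going by the name of the read-out)), compound 2 gives 92.7% and compound 1 gives 91.5%. Among the measured compounds shown here, the one measured step, a number 1.2 percentage points higher from compound 1 to compound 2 (within the scatter), is fluoro in place of hydrogen on an aromatic carbon, and it lies within the scatter; on these two numbers the pair is not distinguished.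

Compound 3, `COCOc1ccccc1C1CC(=O)c2ccccc2O1`, is not yet measured. The change is methoxy in place of 3-fluorophenyl on a saturated chain carbon bound to an oxygen on an aromatic ring. For the measured compounds named here, the measured step touches only the ring that now leaves, so it says nothing about the loss of that ring itself; it shows only that the two measured compounds, with the ring present, sit at the same high level. Because of a number 1.2 percentage points higher from compound 1 to compound 2 (within the scatter) no direction can be read from the data, and a loss of inhibition is possible once the 3-fluorophenyl is gone. Compound 3 is therefore expected at 70% (range 35% to 95%), a step of a number 22.7 percentage points lower from compound 2 to compound 3 (beyond the scatter) expected, with wide uncertainty.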

Compound 3, a percentage reported as inhibition, at one concentration (the size of the read-out at that concentration, not a potency): 33.3%
Beside the measured number, compound 3's estimate is 36.7 percentage points above it, outside the stated range (below it).
By their numbers in this assay, from the lowest: compound 3; then compounds 1 and 2 (each within the scatter of the next).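

In this assay, the change to methoxy on a saturated chain carbon bound to an oxygen on an aromatic ring gives a number 59.4 percentage points lower from compound 2 to compound 3 (beyond the scatter), and the same change in place of phenyl gives a number 58.2 percentage points lower from compound 1 to compound 3 (beyond the scatter). The earlier pair could not be told apart and spoke only to a fluoro on the ring, whereas these steps show that the group at this position matters: with methoxymethyl in place of 3-fluorobenzyl, much of the inhibition is gone. Nothing available on this series explains the loss.

The swap removes the aromatic ring and brings in an oxygen in a single step, so the compounds shown do not separate the two. A cyclohexylmethyl or n-butyl group at this place would bear on that question, as would a pyridylmethyl.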